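Two fluorines in place of methyl at the acid carbon

The compounds below may be only part of what the source reports. "The series", "measured", "known", "first", "only" and "open" are said of these compounds alone.

compound 1 `COc1ccc(F)c([C@H]2CC[C@H](COc3cccc([C@H](C4CC4)[C@H](C)C(=O)O)c3)CC2)c1`: 0.2 nM
compound 2 `COc1ccc(F)c([C@H]2CC[C@H](COc3cccc([C@H](C4CC4)[C@@H](C)C(=O)O)c3)CC2)c1`: 2.2 nM
compound 3 `COc1ccc(F)c([C@H]2CC[C@H](COc3cccc([C@H](C4CC4)[C@@H](F)C(=O)O)c3)CC2)c1`: 1.1 nM

In a functional assay on HEK293 cells for agonist activity at Free fatty acid receptor 1 (Homo sapiens), read by FLIPR and calcium flux (on this read-out lower numbers stand for an effect already at smaller amounts and higher numbers for an effect only at larger amounts of compound), compound 2 gives the highest of the three numbers. Its nearest neighbour is compound 3, with a 2.0-fold lower number from compound 2 to compound 3 (0.30 log units; within the scatter); its furthest is compound 1, with an 11-fold higher number from compound 1 to compound 2 (1.04 log units; beyond the scatter), a large step that rests only on (the fact that compounds 1 and 2 differ only in the configuration as drawn).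

Compound 4 `COc1ccc(F)c([C@H]2CC[C@H](COc3cccc([C@H](C4CC4)C(F)(F)C(=O)O)c3)CC2)c1` carries the change (carboxy(difluoro)methyl in place of 1-carboxyethyl on a saturated chain carbon bound to an aromatic carbon and a saturated ring carbon). Among the measured compounds shown here, two measured steps bear on it. The exchange of one methyl for one fluoro at the same carbon, a 2.0-fold lower number from compound 2 to compound 3 (0.30 log units; within the scatter), stayed within the scatter, while a 5.5-fold higher number from compound 1 to compound 3 (0.74 log units; beyond the scatter) was modest. A second fluorine at that carbon is therefore expected to give a small step, if any, a 1.5-fold lower number from compound 2 to compound 4 (0.17 log units; within the scatter). Compound 4 is estimated at 1.5 nM, with a range from 0.4 nM to 6 nM.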

Compound 4, half-maximal effective concentration: 16 nM
For compound 4 the middle estimate is 11-fold (1.03 log units) below the measured one, and the stated range ends below it.
By their numbers in this assay, from the lowest: compound 1; then compounds 3 and 2 (each within the scatter of the next); then compound 4.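

A second fluorine at this carbon turns out to be no small change: a 15-fold higher number from compound 3 to compound 4 (1.16 log units; beyond the scatter), although putting a single fluoro in place of methyl stayed within the scatter. The difluoro acid also falls behind both methyl compounds, with a 7.3-fold higher number from compound 2 to compound 4 (0.86 log units; beyond the scatter) and an 80-fold higher number from compound 1 to compound 4 (1.90 log units; beyond the scatter), so compound 4 has the highest number of the four. The change also removes the defined stereocentre at this carbon, and nothing shown explains the loss.

Two methyl groups on that carbon would likewise carry no stereocentre there. How such a compound reads would help show whether the loss follows the fluorines or the missing stereocentre.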